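Cytotoxicity Outlook for a Cyanophenyl Analogue

The compounds below may be only part of what the source reports. "The series", "measured", "known", "first", "only" and "open" are said of these compounds alone.

Compound 3 `Cc1cc(-c2cccc(Cl)c2)cc(C)c1Nc1ccnc(Nc2ccc(C#N)cc2)n1` gives 2160 nM in an ADME assay on MT4 cells (Homo sapiens) for cytotoxicity, read by MTT assay, with a stated time of 4 days; on this read-out higher numbers stand for lower toxicity in this test and lower numbers for higher toxicity in this test. Compound 1 `Cc1cccc(-c2cc(C)c(Nc3ccnc(Nc4ccc(C#N)cc4)n3)c(C)c2)c1` with 3670 nM and compound 2 `COc1cccc(-c2cc(C)c(Nc3ccnc(Nc4ccc(C#N)cc4)n3)c(C)c2)c1` with 2990 nM sit close to it: a 1.7-fold lower number from compound 1 to compound 3 (0.23 log units; within the scatter), a 1.4-fold lower number from compound 2 to compound 3 (0.14 log units; within the scatter), and likewise a 1.2-fold lower number from compound 1 to compound 2 (0.09 log units; within the scatter). Compound 4 `Cc1cc(-c2ccc(C#N)cc2)cc(C)c1Nc1ccnc(Nc2ccc(C#N)cc2)n1` differs from compound 3 in one place: 4-cyanophenyl in place of 3-chlorophenyl on an aromatic carbon. The exchanges already tried on that ring, methyl to chloro and methoxy to chloro, bear on this step, and both stayed within the scatter, so no movement beyond the scatter is expected in this assay. Swapping the whole 3-chlorophenyl is a larger change than any seen here, which widens the uncertainty. Compound 4 is therefore estimated at 2500 nM (range 1200 nM to 5500 nM), with a step of a 1.2-fold higher number from compound 3 to compound 4 (0.06 log units; within the scatter) expected.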

Compound 4, half-maximal cytotoxic concentration: 2080 nM
Compound 4: the middle estimate sits 1.2-fold (0.08 log units) above what was measured; measured number inside the range.
By their numbers in this assay, from the lowest: compounds 4, 3, 2 and 1 (each within the scatter of the next).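

In this assay, for the compounds shown here, the 4-cyanophenyl group, the only group at this place that carries a nitrile, stays within the scatter of all three earlier aryl groups: a 1.0-fold lower number from compound 3 to compound 4 (0.02 log units; within the scatter), a 1.4-fold lower number from compound 2 to compound 4 (0.16 log units; within the scatter) and a 1.8-fold lower number from compound 1 to compound 4 (0.25 log units; within the scatter). Among these four compounds, then, the cytotoxicity read-out does not separate the 4-cyanophenyl from the 3-chlorophenyl, 3-methoxyphenyl or 3-methylphenyl, an exchange of the whole ring rather than of one substituent on it. As far as these compounds go, whether an amine or a carboxylic acid on this ring would also stay within the scatter remains open. No evidence is available to explain this result.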